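The source may report more compounds than this note shows. Statements on the series, on what has been measured and on what is new or still open speak of the compounds shown alone.

Of the compounds shown here, two sharing one core have been measured so far in a functional assay on EOL1 cells (Homo sapiens) for inhibition, read by fluorescence, with a stated time of 72 h; a higher number here means a weaker inhibitor of growth, a lower number a stronger inhibitor of growth. Compound 1 (`COc1ccc(Cn2cnc3c(Nc4cccc(Cl)c4)nc(N[C@H]4CC[C@H](N)CC4)nc32)cc1`) gives 530 nM, while compound 2 (`CCCCn1cnc2c(Nc3cccc(Cl)c3)nc(N[C@H]3CC[C@H](N)CC3)nc21`) gives 160 nM, the lower of the two numbers. Compound 3 (`CC(C)=CCC/C(C)=C/Cn1cnc2c(Nc3cccc(Cl)c3)nc(N[C@H]3CC[C@H](N)CC3)nc21`) keeps that core and changes one chain: 2,6-dimethylhepta-1,5-dien-1-yl in place of propyl on a saturated chain carbon bound to an aromatic nitrogen. Thus 2,6-dimethylhepta-1,5-dien-1-yl stands in place of propyl on a saturated chain carbon bound to an aromatic nitrogen. Among the compounds with values here, only one measured step touches this place: a 3.3-fold lower number from compound 1 to compound 2 (0.52 log units; beyond the scatter). That single modest step shows that the number can move with a change here, but it gives no trend for a longer chain with double bonds. A modest rise is therefore expected, though no change beyond the scatter remains possible. The estimated step is a 1.8-fold higher number from compound 2 to compound 3 (0.24 log units; within the scatter). For compound 3 the estimated value is 280 nM, with an expected range from 90 nM to 850 nM.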

Compound 3, concentration for 50% growth inhibition: 590 nM
For compound 3 the middle estimate is 2.1-fold (0.32 log units) below the measured one; measured number inside the range.
By their numbers in this assay, from the lowest: compound 2; then compounds 1 and 3 (each within the scatter of the next).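

In this assay, 2,6-dimethylhepta-1,5-dien-1-yl in place of propyl gives a 3.7-fold higher number from compound 2 to compound 3 (0.57 log units; beyond the scatter), so a second group at this place now stands apart from the propyl of compound 2 beyond the scatter. The same change measured against 4-methoxyphenyl gives a 1.1-fold higher number from compound 1 to compound 3 (0.05 log units; within the scatter), which shows that a chain with no ring and 4-methoxyphenyl cannot be told apart in this assay. No measurement shown here explains either step.

This change adds chain length and double bonds together, so the compounds shown cannot separate the two; 3,7-dimethyloctyl, the saturated counterpart of the new butyl-to-3,7-dimethylocta-2,6-dien-1-yl change, would address that. Also open, going by these compounds, is how a chain of intermediate length, such as hexyl, or a chain ending in an amine would compare.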